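Bromophenyl to Thiophene: From Compound 2 to Compound 4

A few compounds are considered here, and "the series" means these few. Any claim that something is new, unique, unknown or untested is made for them only; others in the source may bear on it.

In a functional assay on A549 cells (Homo sapiens) for antiproliferative activity, read by MTT assay, with a stated time of 48 h (a higher number here means a weaker inhibitor, a lower number a stronger inhibitor), compound 1 `COc1cccc(-c2nc3cccc(-c4cc(OC)c(OC)c(OC)c4)c3o2)c1` gives 3500 nM. Compound 3 `COc1cc(-c2nc3cccc(-c4cc(OC)c(OC)c(OC)c4)c3o2)ccc1O` gives 15700 nM. Compound 2 `COc1cc(-c2cccc3nc(-c4ccc(Br)cc4)oc23)cc(OC)c1OC` reaches only a limit of the assay, > 25000 nM. Of the three values, one sits at the limit of > 25000 nM in this assay, at which 1 of the 3 values shown sits. Compound 2 thus stands beyond compound 1 on the numbers shown, yet with no exact number of its own. Compound 4 `COc1cc(-c2cccc3nc(-c4cccs4)oc23)cc(OC)c1OC` differs from compound 2 in one place: thiophen-2-yl in place of 4-bromophenyl on an aromatic carbon. Two measured steps alter the same group: an at least 7.1-fold higher number from compound 1 to compound 2 (0.85 log units; beyond the scatter), and an at least 1.5-fold lower number from compound 2 to compound 3 (0.20 log units; that floor lies within the scatter). Replacing 4-bromophenyl has so far lowered the number, though for compound 3 only within the scatter. For compound 4 a drop is expected, an at least 2.0-fold lower number from compound 2 to compound 4 (0.31 log units; beyond the scatter), giving an estimated 12000 nM with a range from 3000 nM to 50000 nM.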

Compound 4, half-maximal inhibitory concentration: 12500 nM
Beside the measured number, compound 4's estimate is 1.0-fold (0.02 log units) below it; the range from low to high includes it.
By their numbers in this assay, from the lowest: compound 1; then compounds 4 and 3 (each within the scatter of the next). At a limit, above all of these: compound 2.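

Swapping 4-hydroxy-3-methoxyphenyl for thiophen-2-yl, on the aromatic carbon next to the ring nitrogen and next to the ring oxygen, gives a 1.3-fold lower number from compound 3 to compound 4 (0.10 log units; within the scatter), so a five-membered aromatic ring with sulfur cannot be told apart from that six-membered ring here. Against 3-methoxyphenyl, the same ring gives a 3.6-fold higher number from compound 1 to compound 4 (0.55 log units; beyond the scatter), so compound 1 remains the strongest inhibitor shown. Against 4-bromophenyl, it gives an at least 2.0-fold lower number from compound 2 to compound 4 (0.30 log units; that floor lies within the scatter), and the value of compound 2 is only a limit: the limit of > 25000 nM in this assay, at which 1 of the 4 values shown sits.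

On these data alone, what a furan-2-yl ring would do at this position, or an amine or a carboxylic acid on the thiophen-2-yl ring, stays open.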